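The source may hold more compounds than are shown below. What is called first, only, known or untested is meant among the compounds shown, and "the series" means these compounds.

Measured so far in an ADME assay on MT4 cells (Homo sapiens) for cytotoxicity, read by MTT assay, with a stated time of 5 days; a higher number here means that more compound is tolerated, a lower number that less compound is tolerated:

- compound 1 `COc1cc2nc(Nc3ccc(C#N)cc3)nc(Nc3c(Cl)cc(/C=C/C#N)cc3Cl)c2cc1OC`: 9920 nM
- compound 2 `COc1cc2nc(SCC(=O)Nc3cccc(S(N)(=O)=O)c3)nc(Nc3c(Cl)cc(/C=C/C#N)cc3Cl)c2cc1OC`: > 194000 nM (a limit, not a number)
- compound 3 `COc1cc2nc(SCC(=O)Nc3ccc(S(N)(=O)=O)cc3)nc(Nc3c(Cl)cc(/C=C/C#N)cc3Cl)c2cc1OC`: 116000 nM

Higher numbers here mean that cells tolerate more compound. Compound 1 gives 9920 nM and compound 3 gives 116000 nM, the higher of the two actual numbers, and the gap between them lies beyond the scatter. Compound 2 gives > 194000 nM, which is a limit, so it cannot be ranked as a number.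

The next compound is compound 4 `COc1cc2nc(SCC(=O)Nc3cccc(Cl)c3)nc(Nc3c(Cl)cc(/C=C/C#N)cc3Cl)c2cc1OC`. It has 3-chlorophenyl in place of 4-sulfamoylphenyl on an amide-type nitrogen.

Among the compounds with values here, only one measured step is close to this change: an at least 1.6-fold lower number from compound 2 to compound 3 (0.22 log units; that floor lies within the scatter). That step merely moves the sulfamoyl group, and both compounds keep it, so it says little about losing the group. The other clue is compound 1, which has no sulfamoyl group and stands at 9920 nM, although it also differs from compound 3 elsewhere. A move towards lower numbers is therefore expected, but only loosely. The expected change is a 3.9-fold lower number from compound 3 to compound 4 (0.59 log units; beyond the scatter). For compound 4 the estimated value is 30000 nM, with an expected range from 8000 nM to 110000 nM.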

Compound 4, half-maximal cytotoxic concentration: > 208000 nM
Compound 4: no number, only a limit; the forecaster's own chance of this, stated with the estimate: 20%; middle value at least 6.9-fold (0.84 log units) from the limit.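

In this assay the result for compound 4 is a limit and not a number: the limit of > 208000 nM in this assay, at which 1 of the 4 values shown sits. On the amide-type nitrogen, 3-chlorophenyl in place of 4-sulfamoylphenyl gives an at least 1.7-fold higher number from compound 3 to compound 4 (0.25 log units; that floor lies within the scatter), so this change brings no measurable fall, and the sulfamoyl group that compound 2 and compound 3 both carry is not needed for a high tolerated concentration in this small series. The low number of compound 1 also looks different now: the replacement of its (4-cyanophenyl)amino group by the ((3-chlorophenyl)carbamoyl)methyl)sulfanyl group gives an at least 20-fold higher number from compound 1 to compound 4 (1.32 log units; beyond the scatter), which ties the gap to that group on the aromatic carbon and not to the absence of sulfamoyl.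

On these data alone, the step joining compound 2 and compound 4 cannot be read, and how far compound 4 lies past its limit stays unknown. Also open, as far as these compounds go, is whether a different group on the amide-type nitrogen, such as a phenyl ring carrying a carboxylic acid or an amine, or a longer chain in place of the ring, would lower the number in this assay.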